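The source may report more compounds than this note shows. Statements on the series, on what has been measured and on what is new or still open speak of the compounds shown alone.

Of the compounds shown here, three built on one shared core have been tested in a functional assay on MCF7 cells (Homo sapiens) for inhibition, read by MTT assay, with a stated time of 24 h; on this read-out lower numbers stand for stronger inhibition and higher numbers for weaker inhibition. Compound 1 `CCOC(=O)C1=Cc2ccccc2OC1(OCc1cc(-c2ccc(OC)cc2)no1)C(F)(F)F` reaches only the limit of the assay, > 150000 nM. Compound 3 `O=C(O)C1=Cc2ccccc2OC1(OCc1cc(-c2ccc3ccccc3c2)no1)C(F)(F)F` likewise gives a limit, > 150000 nM. Compound 2 `CCCCCCCCn1cc(COC2(C(F)(F)F)Oc3ccccc3C=C2C(=O)OCC)nn1` also returns a limit, > 150000 nM, so no number sets it apart from the others. All three values sit at the limit of > 150000 nM in this assay, at which 3 of the 3 values shown sit. Compound 4 `CCOC(=O)C1=Cc2ccccc2OC1(OCc1cn(-c2ccc([N+](=O)[O-])cc2)nn1)C(F)(F)F` differs from compound 2 in one place: 4-nitrophenyl in place of octyl on an aromatic nitrogen. Within the data shown here, no step between two measured compounds is available, so nothing shows what this change does on its own. With every measured compound at the limit, the step that the limit leaves unreadable from compound 2 to compound 4 is expected to stay within the scatter, and a limit again is the most likely outcome. Compound 4 is therefore estimated at 200000 nM, within 100000 nM to 400000 nM.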

Compound 4, half-maximal inhibitory concentration: > 150000 nM
Compound 4 gave a limit, no number; the forecaster's own chance of this, stated with the estimate: 80%; the middle value lies beyond the limit too.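

Among these compounds, compound 2 and compound 4 both stop at the assay limit, so swapping octyl for 4-nitrophenyl gives no step that can be read. The compounds shown leave open which structural change, if any, would give a real number on this shared core.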